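Working notes: isopentyl step from compound 2

The source may hold more compounds than are shown below. What is called first, only, known or untested is meant among the compounds shown, and "the series" means these compounds.

Measured so far in an ADME assay on Vero cells (Chlorocebus sabaeus) for cytotoxicity, read by resazurin assay, with a stated time of 24 h; on this read-out higher numbers stand for lower toxicity in this test and lower numbers for higher toxicity in this test
- compound 1 (`CCCCO[C@@H]1C=CC(=O)[C@@H](COC(=O)C(C)(C)C)O1`): (42500 nM)
- compound 2 (`CC(=O)OC[C@H]1O[C@H](OC(C)C)C=CC1=O`): (104000 nM)
- compound 3 (`Cc1ccc(S(=O)(=O)OC[C@H]2O[C@H](OC(C)C)C=CC2=O)cc1`): (13400 nM)

In this assay compound 2 holds the highest number of the three (104000 nM), and the other two compounds both lie lower, beyond the scatter. Compound 4 (`CC(=O)OC[C@H]1O[C@H](OCCC(C)C)C=CC1=O`) keeps the rest of compound 2 and carries isopentyl in place of isopropyl on an oxygen on a saturated carbon.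

Going by the values given here, no measured pair isolates this change, so the expectation rests on little. Compound 2 at 104000 nM sits at the top of a very small set, and compound 1 at 42500 nM is the nearest value, so a move toward lower numbers seems more likely than a rise. A small step toward a lower number is expected (a 1.7-fold lower number from compound 2 to compound 4 (0.24 log units; within the scatter)). For compound 4 the estimated value is 60000 nM with an expected range from 25000 nM to 120000 nM and this remains a loose estimate.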

Compound 4, half-maximal cytotoxic concentration: 19800 nM
Estimate against measurement, compound 4: 3.0-fold (0.48 log units) above; the whole stated range lies above it.
By their numbers in this assay, from the lowest: compounds 3 and 4 (each within the scatter of the next); then compound 1; then compound 2.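

In this assay, going by these compounds alone, this is the first pair that differs in one place, and it shows that the group on this oxygen affects the read-out: isopentyl in place of isopropyl gives a step beyond the scatter (a 5.3-fold lower number from compound 2 to compound 4 (0.72 log units; beyond the scatter)). The earlier compounds shown here differ from one another in more than one place, so they could not separate this group from the rest of the structure. No measurement at hand bears on what lies behind the step.

A single step cannot show whether the number keeps falling as the chain grows, or whether a longer chain such as octyl, or a chain ending in an amine, on the same oxygen would follow the same direction. On these data alone, whether this change gives a similar step on the rest of compound 3 also remains open.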